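The source may hold more compounds than are shown below. What is called first, only, known or untested is meant among the compounds shown, and "the series" means these compounds.

Measured in a functional assay on A549 cells (Homo sapiens) for antiproliferative activity, read by MTT assay, with a stated time of 72 h; on this read-out higher numbers stand for weaker inhibition and lower numbers for stronger inhibition:
- compound 1 `COc1cc(C(=O)c2sc3ccccc3c2-c2ccc(Cl)cc2)cc(OC)c1OC`: 7500 nM
- compound 2 `COc1ccc(-c2c(C(=O)c3cc(OC)c(OC)c(OC)c3)sc3ccccc23)cc1`: 4400 nM
- compound 3 `COc1ccccc1-c1c(C(=O)c2cc(OC)c(OC)c(OC)c2)sc2ccccc12`: > 10000 nM (a limit, not a number)

For compound 3, only a limit is known, > 10000 nM. Compound 4 `COc1ccc(OC)c(-c2c(C(=O)c3cc(OC)c(OC)c(OC)c3)sc3ccccc23)c1` differs from it by methoxy in place of hydrogen on an aromatic carbon, turning 2-methoxyphenyl into 2,5-dimethoxyphenyl. Among the measured compounds shown here, no measured step adds this group, so the evidence is indirect. Swapping the substituent on the same aromatic ring gave a 1.7-fold lower number from compound 1 to compound 2 (0.23 log units; within the scatter). Replacing 4-methoxyphenyl with 2-methoxyphenyl gave an at least 2.2-fold higher number from compound 2 to compound 3 (0.35 log units; beyond the scatter). Those steps suggest a modest change at most, with little expected beyond the scatter in this assay. The expected change is an at least 1.1-fold lower number from compound 3 to compound 4 (0.04 log units; that floor lies within the scatter). For compound 4 the estimate is 9000 nM, with an expected range of 4000 nM to 20000 nM.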

Compound 4, half-maximal inhibitory concentration: > 10000 nM
Compound 4 gave a limit, no number; the forecaster's own chance of this, stated with the estimate: 55%; at least 1.1-fold (0.04 log units) between middle value and limit.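

In this assay compound 4 gives > 10000 nM, which is a limit and not a number. So adding this methoxy does not bring the 2,5-dimethoxyphenyl compound into the measurable range, and the new compound compares with the earlier ones as an at least 2.2-fold higher number from compound 2 to compound 4 (0.35 log units; beyond the scatter) and an at least 1.3-fold higher number from compound 1 to compound 4 (0.12 log units; that floor lies within the scatter). The step that adds the methoxy to compound 3 cannot be read, and both compounds share one limit: the limit of > 10000 nM in this assay, at which 2 of the 4 values shown sit.

Still open, from the compounds shown here alone, is how large the effect of this methoxy really is. Also open, going by these compounds, is whether another group at this place, such as a hydroxyl or an amine, would give a real number in this assay.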